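A few compounds are considered here, and "the series" means these few. Any claim that something is new, unique, unknown or untested is made for them only; others in the source may bear on it.

Two measured compounds frame the question. Compound 1 `ClCc1ccccc1Cn1cnc2c(Cl)nc(Cl)nc21` and compound 2 `ClCc1cccc(Cn2cnc3ncnc(Cl)c32)c1` share a purine-type core but differ in more than one place: compound 1 carries two chloro groups on its core and a chloromethyl on the benzyl ring, while compound 2 carries one chloro on the core and a chloromethyl set elsewhere on the benzyl ring. In a functional assay on ACHN cells (Homo sapiens) for cytotoxicity, read by sulforhodamine B assay, with a stated time of 48 h (on this read-out higher numbers stand for weaker inhibition of growth and lower numbers for stronger inhibition of growth), compound 1 gives 470 nM, and in this assay compound 2 gives 1860 nM. Compound 2 thus holds the higher of the two numbers, and the gap to compound 1 lies beyond the scatter.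

Compound 3 `ClCc1cccc(Cn2cnc3nc(Cl)nc(Cl)c32)c1` has not been measured. It differs from compound 2 in a single place: chloro in place of hydrogen on an aromatic carbon. Going by the values given here, no step between two measured compounds isolates this change, so the expectation rests on the two values alone. Since compound 1, which also carries this second chloro on its core, gives 470 nM, the added chloro is expected to move compound 3 toward stronger inhibition of growth. The estimated step from compound 2 to compound 3 in this assay is a 2.9-fold lower number from compound 2 to compound 3 (0.46 log units; beyond the scatter). Compound 3 is therefore expected to give about 650 nM in this assay, within a range from 250 nM to 1700 nM.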

Compound 3, concentration for 50% growth inhibition: 1120 nM
The estimate for compound 3 lay 1.7-fold (0.24 log units) below the measured number; the measured number falls inside the stated range.
By their numbers in this assay, from the lowest: compound 1; then compounds 3 and 2 (each within the scatter of the next).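

In this assay, chloro in place of hydrogen on an aromatic carbon between two ring nitrogen atoms gives a 1.7-fold lower number from compound 2 to compound 3 (0.22 log units; within the scatter), so compound 2 and compound 3 cannot be told apart on this read-out. Going by these compounds alone, this is the first reading of this change on its own, since the second chloro in compound 1 came together with a different placement of the chloromethyl on the benzyl ring. No measurement shown here bears on why the step has this size.

The compounds shown leave open how an amine, a methoxy group or a thioether would read on this same aromatic carbon, since only hydrogen and chloro stand there so far. They also leave open whether chloro in place of hydrogen at this position would give a similar step with the chloromethyl placed as in compound 1, as that compound has no partner carrying hydrogen at this position.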